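This account rests on a few compounds, and the source may have more. Where it says the series, first, only, none or still open, it means among the compounds named here.

Measured so far in an assay on isolated protein for inhibition of histone deacetylase 8 (Homo sapiens), with a stated time of 1 h; on this read-out lower numbers stand for stronger inhibition and higher numbers for weaker inhibition:
Compound 1 `COc1cccc(NC(=O)COc2ccc3cc(/C=C4/SC(=O)NC4=O)ccc3c2)c1`: 7600 nM
Compound 2 `CCOc1ccc2nc(NC(=O)COc3ccc4cc(/C=C5/SC(=O)NC5=O)ccc4c3)sc2c1`: 17000 nM
Compound 3 `O=C(COc1ccc2cc(/C=C3/SC(=O)NC3=O)ccc2c1)Nc1ccccc1Oc1ccccc1`: > 50000 nM, a limit of the assay rather than a number

Among the two numbers obtained, compound 1 stands lowest, and compound 2 comes next with a gap that is beyond the usual scatter. For compound 3 the assay reports only (the limit of > 50000 nM in this assay, at which 1 of the 3 values shown sits). Compound 4 `O=C(COc1ccc2cc(/C=C3/SC(=O)NC3=O)ccc2c1)Nc1ccc(Cl)c(Cl)c1` has not yet been measured in this assay. It differs from compound 1 in one place: 3,4-dichlorophenyl in place of 3-methoxyphenyl on an amide-type nitrogen. Going by the values given here, no measured pair shows a change of this kind, so there is no step to lean on, and the aryl amide of compound 1 remains the closest reference at 7600 nM. Since the core and the amide linkage are kept and only the substituents on the aryl ring change, compound 4 is expected to stay close to compound 1, with no step beyond the scatter in either direction, a 1.2-fold lower number from compound 1 to compound 4 (0.07 log units; within the scatter). Compound 4 is therefore estimated at 6500 nM, with a range from 2500 nM to 20000 nM.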

Compound 4, half-maximal inhibitory concentration: > 50000 nM
Compound 4 was reported as a limit; the forecaster's own chance of this, stated with the estimate: 10%; middle value at least 7.6-fold (0.88 log units) from the limit.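

In this assay, the aryl group on the amide-type nitrogen proves sensitive to its substituents even with the core and the amide linkage kept, as 3,4-dichlorophenyl in place of 3-methoxyphenyl gives an at least 6.5-fold higher number from compound 1 to compound 4 (0.81 log units; beyond the scatter). Going by these compounds alone, this is the first step measured at this position; both groups hold one six-membered aromatic ring and the same number of heavy atoms, so only the substituents on that ring differ. From the compounds shown here alone, compound 4 is reported only as a limit, so the full size of the step stays unknown, and the limit is now shared with compound 3: the limit of > 50000 nM in this assay, at which 2 of the 4 values shown sit.

The compounds shown leave open whether an unsubstituted phenyl group on this nitrogen would stay near compound 1. They also do not tell whether a carboxylic acid or an amine on the ring would lower the number.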